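Trading an Amide for an Ester on the Aryl Arm

The source may hold more compounds than are shown below. What is called first, only, known or untested is meant among the compounds shown, and "the series" means these compounds.

Of the compounds shown here, three that share one core have been measured in an assay for inhibition of 15-hydroxyprostaglandin dehydrogenase [NAD(+)] (Homo sapiens), read by fluorescence, with a stated time of 15 min, in the presence of a further agent that is not named here; on this read-out lower numbers stand for stronger inhibition and higher numbers for weaker inhibition. Compound 1 `CCCC[S+]([O-])c1sc2nc(-c3nccs3)cc(-c3ccc(C(=O)N(C)C)cc3)c2c1N` gives 5.9 nM in this assay, the lowest of the three numbers. Compound 2 `Nc1c([S+]([O-])CCCF)sc2nc(-c3cccs3)cc(-c3ccccc3)c12` gives 6.1 nM, a value that sits within the scatter of compound 1, so the two cannot be ranked against each other. Compound 3 `CCC[S+]([O-])c1sc2nc(-c3cccs3)cc(C(=O)N(C)C)c2c1N` gives 14.7 nM, a number that lies beyond the scatter above compound 1, so compound 3 is the weaker inhibitor of that pair.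

Compound 4 `CCCC[S+]([O-])c1sc2nc(-c3nccs3)cc(-c3ccc(C(=O)OC)cc3)c2c1N` has not yet been measured. It differs from compound 1 in one place: methoxy in place of dimethylamino on a carbonyl carbon. The rest of the molecule, including the core and the ring that carries the carbonyl, is unchanged.

For the measured compounds named here, no measured pair shows this exact change, so the expectation rests on compound 1 alone. Since the change is small and confined to the end of one arm, the step from compound 1 to compound 4 is expected to be a 1.7-fold higher number from compound 1 to compound 4 (0.23 log units; within the scatter), a modest shift toward a higher number, possibly not beyond the scatter. Compound 4 is therefore estimated to give about 10 nM in this assay, with a likely range from 4 nM to 25 nM.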

Compound 4, half-maximal inhibitory concentration: 15.1 nM
For compound 4 the middle estimate is 1.5-fold (0.18 log units) below the measured one, and the stated range covers the measured number.
By their numbers in this assay, from the lowest: compounds 1 and 2 (each within the scatter of the next); then compounds 3 and 4 (each within the scatter of the next).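

In this assay, for the compounds shown here, putting methoxy in place of dimethylamino on a carbonyl carbon gives a 2.6-fold higher number from compound 1 to compound 4 (0.41 log units; beyond the scatter), the first step here in which only one place changes. The shift is modest, but it lies beyond the scatter, so the amide compound 1 can be ranked as the stronger inhibitor of this pair, and what sits on this carbonyl carbon affects the result. No measurement here bears on why the number rises, so this remains an observation about one pair of compounds.

The compounds shown leave open how other groups on the same carbonyl carbon would compare, such as a carboxylic acid, an ethyl ester or an amide carrying a longer chain on its nitrogen. As far as these compounds go, it also remains open whether this change would give a step of similar size with a different chain on the sulfur or a different ring on the shared core, since it is seen here in a single setting.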